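A Hydroxy Group on the Sulfonamide Chain of Compound 2

The compounds below may be only part of what the source reports. "The series", "measured", "known", "first", "only" and "open" are said of these compounds alone.

Compound 1 `CC1(C)C=C(n2ccccc2=O)c2cc(S(=O)(=O)N=[N+]=[N-])ccc2O1` gives 77.2% in a functional assay on the whole organism (trachea) with Rattus norvegicus as the target; on this read-out lower numbers stand for smaller maximal responses and higher numbers for larger maximal responses.
Compound 2 `CCNS(=O)(=O)c1ccc2c(c1)C(n1ccccc1=O)=CC(C)(C)O2` gives 87% in this assay.

Among the compounds with values here, compound 2 gives the larger of the two numbers, yet the only measured step, a number 9.8 percentage points higher from compound 1 to compound 2 (within the scatter), lies within the scatter. Compound 3 `CC1(C)C=C(n2ccccc2=O)c2cc(S(=O)(=O)NCCO)ccc2O1` differs from compound 2 by hydroxy in place of hydrogen on a saturated chain carbon, two bonds along the chain from a sulfonamide nitrogen. Within the data shown here, no measured step touches this chain carbon, and the one step known, a replacement on the sulfonyl sulfur, stayed within the scatter, so in this assay no step beyond the scatter is expected in either direction. Compound 3 is therefore estimated at 85%, between 70% and 98%. For compound 3 the expected step is a number 2 percentage points lower from compound 2 to compound 3 (within the scatter).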

Compound 3, largest response reached (Emax), in percent of the reference or control that the assay uses: 87.9%
Compound 3: middle estimate off by 2.9 percentage points, on the low side, within the range that was stated.
By their numbers in this assay, from the lowest: compounds 1, 2 and 3 (each within the scatter of the next, the first and the last beyond it).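

In this assay, within the data shown here, the change from ethylamino to (2-hydroxyethyl)amino gives a number 0.9 percentage points higher from compound 2 to compound 3 (within the scatter), so hydroxy on this saturated chain carbon produces no step that can be told from the scatter. Replacing azido on the sulfonyl sulfur with (2-hydroxyethyl)amino gives a number 10.7 percentage points higher from compound 1 to compound 3 (beyond the scatter), the only step shown that passes the scatter, and only modestly. Nothing available accounts for either step.

Going by these compounds, whether an amine or a carboxylic acid in place of the hydroxy, or a longer chain carrying it, would shift the maximal response remains open.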